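The source may report more compounds than this note shows. Statements on the series, on what has been measured and on what is new or still open speak of the compounds shown alone.

In a functional assay on SMMC-7721 cells (Homo sapiens) for inhibition, read by CCK-8 assay, with a stated time of 72 h, tested at 2 uM (on this read-out higher numbers stand for more inhibition of growth at the one concentration tested and lower numbers for less inhibition of growth), compound 1 `CCc1ccc(SCc2ccc(C(=O)Nc3ccccc3N)cc2)cc1` gives 25.7%. Compound 2 `COC(=O)c1ccccc1SCc1ccc(C(=O)Nc2ccccc2N)cc1` gives 18%, so the two values lie within the usual scatter of each other and compound 1 does not stand apart. Compound 3 `Cc1cc(C)cc(SCc2ccc(C(=O)Nc3ccccc3N)cc2)c1` has 3,5-dimethylphenyl in place of 4-ethylphenyl on a sulfur. Within the data shown here, no measured step between compounds differing in one place is available, so the expectation rests only on these two values. The expected step of a number 1.7 percentage points lower from compound 1 to compound 3 (within the scatter) in this assay stays within the scatter, with no firm direction. For compound 3 the estimated value is 24%, with an expected range of 12% to 38%.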

Compound 3, percent growth inhibition at one concentration: 29.1%
Beside the measured number, compound 3's estimate is 5.1 percentage points below it; measured number inside the range.
By their numbers in this assay, from the lowest: compounds 2, 1 and 3 (each within the scatter of the next, the first and the last beyond it).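

At this place, on a sulfur whose other neighbour is a saturated chain carbon, 3,5-dimethylphenyl in place of 4-ethylphenyl gives a number 3.4 percentage points higher from compound 1 to compound 3 (within the scatter) in this assay. Among these compounds, this is the first one-place step, and this assay does not separate these two arrangements of the same atoms. No measurement available here accounts for this result.

Still open, on these data alone, is whether a different group at this place, such as an amine, a carboxylic acid or a longer chain, would move growth inhibition beyond the scatter.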